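Trimming the piperazine side chain of compound 3

This account rests on a few compounds, and the source may have more. Where it says the series, first, only, none or still open, it means among the compounds named here.

Measured in a functional assay on MCF7 cells (Homo sapiens) for cytotoxicity, read by MTT assay, with a stated time of 72 h; on this read-out lower numbers stand for stronger inhibition and higher numbers for weaker inhibition:
Compound 1 `O=C1c2c[n+]([O-])c3ccccc3c2C(=O)c2c1c1ccccc1n2Cc1cn(CC(O)CO)nn1`: 1110 nM
Compound 2 `CN1CCN(CCCCn2c3c(c4ccccc42)C(=O)c2c[n+]([O-])c4ccccc4c2C3=O)CC1`: 100 nM
Compound 3 `CCCN1CCN(CCCCn2c3c(c4ccccc42)C(=O)c2c[n+]([O-])c4ccccc4c2C3=O)CC1`: 1280 nM

Compound 3, at 1280 nM, sits level with compound 1, as a 1.2-fold higher number from compound 1 to compound 3 (0.06 log units; within the scatter) shows. Both lie well away from compound 2, which stands at 100 nM.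

The next compound is compound 4 `CN1CCN(CCCn2c3c(c4ccccc42)C(=O)c2c[n+]([O-])c4ccccc4c2C3=O)CC1`, and it differs from compound 3 by 4-methylpiperazin-1-yl in place of (4-propylpiperazin-1-yl)methyl on a saturated chain carbon, three bonds along the chain from an aromatic nitrogen. Put simply, 4-methylpiperazin-1-yl comes in place of (4-propylpiperazin-1-yl)methyl on a saturated chain carbon, three bonds along the chain from an aromatic nitrogen. Read one bond further out, 3-(4-propylpiperazin-1-yl)propyl gives way to 2-(4-methylpiperazin-1-yl)ethyl, so the end group and the chain change together.

The closest guide is a 13-fold higher number from compound 2 to compound 3 (1.11 log units; beyond the scatter), where the end group alone changes. Compound 4 carries the same 4-methylpiperazin-1-yl group as compound 2, so that step, run backwards, points to a much lower number. The other large step, an 11-fold lower number from compound 1 to compound 2 (1.05 log units; beyond the scatter), swaps a wholly different side chain and says little here. Among the measured compounds shown here, no measured pair isolates the chain change, so only part of that gain is expected to carry over.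

The expected change is a 5.1-fold lower number from compound 3 to compound 4 (0.71 log units; beyond the scatter), a clear move towards stronger inhibition.

The estimate for compound 4 is 250 nM, with an expected range from 80 nM to 800 nM.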

Compound 4, half-maximal inhibitory concentration: 220 nM
Estimate against measurement, compound 4: 1.1-fold (0.06 log units) above; the range from low to high includes it.
By their numbers in this assay, from the lowest: compound 2; then compound 4; then compounds 1 and 3 (each within the scatter of the next).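

In this assay, the change in chain can now be read apart from the end group, since a 2.2-fold higher number from compound 2 to compound 4 (0.34 log units; beyond the scatter) keeps the 4-methylpiperazine end and swaps only 3-(4-methylpiperazin-1-yl)propyl for 2-(4-methylpiperazin-1-yl)ethyl, and this modest step lies beyond the scatter. Set beside the end-group change alone, a 13-fold higher number from compound 2 to compound 3 (1.11 log units; beyond the scatter), the double change in a 5.8-fold lower number from compound 3 to compound 4 (0.76 log units; beyond the scatter) shows that most of the difference between the methyl and propyl compounds survives on the shorter chain, with a moderate cost from shortening. The shorter chain also keeps an advantage over the triazole side chain in a 5.0-fold lower number from compound 1 to compound 4 (0.70 log units; beyond the scatter), although that step replaces the whole side chain and cannot single out any one feature.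

Still open, as far as these compounds go, is whether the same chain effect holds with a propyl end group, as in 2-(4-propylpiperazin-1-yl)ethyl, and how a morpholine end group or a chain longer than 3-(4-methylpiperazin-1-yl)propyl would compare. No supporting measurement is available to explain any of these shifts.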